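The source may report more compounds than this note shows. Statements on the series, on what has been measured and on what is new or still open speak of the compounds shown alone.

Measured so far:
- compound 1, `N/C(=N/NC(CC(=O)c1ccc(-n2ccnc2)cc1)c1ccc(F)cc1)c1ccccn1`: 78800 nM
- compound 2, `N/C(=N/NC(CC(=O)c1ccc(-n2ccnc2)cc1)c1cccc(Cl)c1)c1ccccn1`: 68600 nM

Both numbers come from an ADME assay on Vero cells (Chlorocebus sabaeus) for cytotoxicity, read by MTT assay, with a stated time of 72 h; on this read-out higher numbers stand for lower toxicity in this test and lower numbers for higher toxicity in this test. Compound 1 stands at the top of these two numbers, but only by a 1.1-fold lower number from compound 1 to compound 2 (0.06 log units; within the scatter), so on this test compound 1 and compound 2 cannot be told apart.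

The unmeasured compound 3, `N/C(=N/NC(CC(=O)c1ccc(-n2ccnc2)cc1)c1ccccc1F)c1ccccn1`, keeps the shared core of compound 1 and differs from it by 2-fluorophenyl in place of 4-fluorophenyl on a saturated chain carbon bound to an amine nitrogen and a saturated chain carbon. Among the compounds with values here, the one measured step that bears on this change is the one at the same place, a 1.1-fold lower number from compound 1 to compound 2 (0.06 log units; within the scatter), where exchanging one aryl group for another at that saturated chain carbon left the number within the scatter. That single step is slender ground, but it is the only ground there is, and nothing in it points to a change beyond the scatter when the fluorine is moved within the same kind of ring.

For this reason compound 3 is expected to sit close to compound 1, with a step of a 1.1-fold lower number from compound 1 to compound 3 (0.04 log units; within the scatter) in this assay. The estimate for compound 3 is 72000 nM, with a range from 36000 nM to 145000 nM.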

Compound 3, half-maximal cytotoxic concentration: 62100 nM
Beside the measured number, compound 3's estimate is 1.2-fold (0.06 log units) above it; the measured number falls inside the stated range.
By their numbers in this assay, from the lowest: compounds 3, 2 and 1 (each within the scatter of the next).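

A step of a 1.3-fold lower number from compound 1 to compound 3 (0.10 log units; within the scatter) in this assay shows that exchanging 4-fluorophenyl for 2-fluorophenyl, two groups with the same atoms joined differently, on a saturated chain carbon bound to an amine nitrogen and a saturated chain carbon does not separate the two compounds in this test. A step of a 1.1-fold lower number from compound 2 to compound 3 (0.04 log units; within the scatter) shows that 2-fluorophenyl and 3-chlorophenyl cannot be told apart at this place either. Compounds 1, 2 and 3 therefore lie within the scatter of one another, so none of these three aryl groups stands out from the others here.

No supporting information is available on why these numbers lie so close together. All three compounds carry a halogen-bearing phenyl group at this place, which leaves open whether a different kind of group there, such as an amine, a carboxylic acid or a longer alkyl chain, would also stay within the scatter or would give a clearly different number.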